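Benzyl ether series: bromo in place of nitro

This account rests on a few compounds, and the source may have more. Where it says the series, first, only, none or still open, it means among the compounds named here.

Compound 1 `CS(=O)(=O)Nc1ccc([N+](=O)[O-])cc1OCc1ccc([N+](=O)[O-])cc1` gives 400 nM in an assay on SK-BR-3 cells for inhibition of Aromatase (Homo sapiens) (on this read-out lower numbers stand for stronger inhibition and higher numbers for weaker inhibition), the second highest of the three numbers in hand. Compound 3 `CS(=O)(=O)Nc1ccc([N+](=O)[O-])cc1OCc1ccccc1-c1ccccc1` gives 260 nM, and the two values lie within the scatter of each other, so no order is read between them. Among the measured compounds shown here, compound 2 `CS(=O)(=O)Nc1ccc([N+](=O)[O-])cc1OCc1ccc2ccccc2c1` gives 2170 nM, the only number beyond the scatter from compound 1. Compound 4 `CS(=O)(=O)Nc1ccc([N+](=O)[O-])cc1OCc1ccc(Br)cc1` differs from compound 1 by bromo in place of nitro on an aromatic carbon. For the measured compounds named here, no measured pair shows this change, so the step from compound 1 to compound 4 in this assay is expected to be small, in no firm direction, and probably within the scatter. Compound 4 is therefore estimated at 500 nM, with a range from 200 nM to 1300 nM. This estimate means a step of a 1.3-fold higher number from compound 1 to compound 4 (0.10 log units; within the scatter).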

Compound 4, half-maximal inhibitory concentration: 5850 nM
For compound 4 the middle estimate is 12-fold (1.07 log units) below the measured one, and the stated range ends below it.
By their numbers in this assay, from the lowest: compounds 3 and 1 (each within the scatter of the next); then compound 2; then compound 4.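

In this assay, among the compounds shown here, bromo in place of nitro on an aromatic carbon para to a large group gives a 15-fold higher number from compound 1 to compound 4 (1.17 log units; beyond the scatter) and is the only single-place step so far. The position is therefore not indifferent to its substituent, and bromo does not stand in for nitro on this core. No measurement in hand bears on the cause of the step. Open, going by these compounds, is how a nitrile or a carboxylic acid at the same place would read out. This single pair also leaves open whether the same change would give a step of similar size on the other benzyl ethers.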